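An allyloxy to ethoxy step on the shared core

The compounds below may be only part of what the source reports. "The series", "measured", "known", "first", "only" and "open" are said of these compounds alone.

Measured so far:
compound 1 `C=CCOc1ccc2c(NCCN(C)C)ccnc2c1` — 930 nM
compound 2 `Clc1ccnc2cc(OCCCc3ccccc3)ccc12` — 630 nM

Of the compounds shown here, two have been tested in a functional assay on NCI-H1650 cells (Homo sapiens) for cytotoxicity, read by MTT assay, with a stated time of 48 h; on this read-out lower numbers stand for stronger inhibition and higher numbers for weaker inhibition. Compound 1 gives 930 nM, the higher of the two numbers; compound 2 gives 630 nM. The distance between compound 1 and compound 2 falls within the usual scatter of this assay, so the two cannot be told apart on these data.

Compound 3 `CCOc1ccc2c(NCCN(C)C)ccnc2c1` has not yet been measured. It differs from compound 1 in one place: methyl in place of vinyl on a saturated chain carbon bound to an oxygen on an aromatic ring. Among the measured compounds shown here, no pair of measured compounds shows a change of this kind, so there is no measured step to lean on; the change is small, and the expectation is that it moves the number no further than the scatter allows, in no particular direction. Compound 3 is therefore expected near 1100 nM, with a range from 400 nM to 3000 nM. That expectation amounts to a step of a 1.2-fold higher number from compound 1 to compound 3 (0.07 log units; within the scatter).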

Compound 3, half-maximal inhibitory concentration: 3490 nM
Beside the measured number, compound 3's estimate is 3.2-fold (0.50 log units) below it, and the stated range ends below it.
By their numbers in this assay, from the lowest: compounds 2 and 1 (each within the scatter of the next); then compound 3.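

In this assay, the change from allyloxy to ethoxy gives a 3.8-fold higher number from compound 1 to compound 3 (0.57 log units; beyond the scatter), a modest step but one beyond the scatter. Among the compounds shown here, this shows what the earlier compounds could not: the number at this position on the shared core responds to a small change, one carbon fewer and no double bond outside the aromatic rings, and here the change runs toward weaker inhibition. Nothing in the data given explains why this step occurs.

For the compounds shown here, the single step leaves open whether the lost carbon or the lost double bond matters more; a propoxy group, which keeps the allyloxy chain length as a saturated chain, would separate the two. It also leaves open how the number would move with a methoxy group or a longer alkoxy chain on the same core.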